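The source may hold more compounds than are shown below. What is called first, only, known or untested is meant among the compounds shown, and "the series" means these compounds.

Two compounds share a core and were tested in a functional assay on the whole organism for inhibition of sodium-dependent dopamine transporter (Mus musculus); a lower number here means that less compound is needed, a higher number that more compound is needed for the effect. Compound 1 `CCOC(=O)Nc1cccc2c1CN(C)CC2c1ccc(Cl)cc1` gives 21 mg/kg. Compound 2 `CCCCOC(=O)Nc1cccc2c1CN(C)CC2c1ccccc1` gives 12 mg/kg, and these two numbers lie within the scatter of each other, so neither can be set apart. Compound 3 `CCNCCC(=O)Nc1cccc2c1CN(C)CC2c1ccccc1` differs from compound 2 by 2-(ethylamino)ethyl in place of butoxy on a carbonyl carbon. Among the measured compounds shown here, since no measured pair shows this change, only a cautious expectation is possible: compound 3 is estimated to come out near compound 2, with a step of a 1.3-fold higher number from compound 2 to compound 3 (0.10 log units; within the scatter) that is not expected to exceed the scatter. The estimate for compound 3 is 15 mg/kg, within a range from 6 mg/kg to 40 mg/kg.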

Compound 3, dose for half-maximal effect: 190 mg/kg
Compound 3: middle estimate off by 13-fold (1.10 log units), on the low side; measured number outside the range, above it.
By their numbers in this assay, from the lowest: compounds 2 and 1 (each within the scatter of the next); then compound 3.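

The carbonyl carbon whose other neighbour is the amide-type nitrogen proves sensitive to what it carries: in this assay the exchange of butoxy for 2-(ethylamino)ethyl gives a 16-fold higher number from compound 2 to compound 3 (1.20 log units; beyond the scatter) and is a large step. The two groups match in heavy-atom count, yet only the entering one carries a hydrogen-bond donor. No measurement at hand accounts for the step. As far as these compounds go, a plain butyl chain or a 2-(dimethylamino)ethyl group on the same carbonyl carbon could separate the loss of the oxygen from the arrival of the amine, and that separation remains open.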